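From compound 3 to compound 4: a nitro for a fluoro

This account rests on a few compounds, and the source may have more. Where it says the series, first, only, none or still open, it means among the compounds named here.

In a functional assay on WiDr cells (Homo sapiens) for inhibition (on this read-out lower numbers stand for stronger inhibition and higher numbers for weaker inhibition), three compounds have been measured. Compound 1 `CCOC(=O)CNC(=O)N1CC1C#N` gives 31000 nM, compound 2 `CCCCNC(=O)N1CC1C#N` gives 14000 nM, and compound 3 `N#CC1CN1C(=O)Nc1ccc(F)cc1` gives 2100 nM. Compound 3 thus stands lowest of the three, and its gaps to compound 2 and to compound 1 both lie beyond the usual scatter, so it is the strongest inhibitor seen so far. Compound 4 `N#CC1CN1C(=O)Nc1ccc([N+](=O)[O-])cc1` has not yet been measured; it differs from compound 3 by nitro in place of fluoro on an aromatic carbon. For the measured compounds named here, no measured pair shows what this exchange does, so only a small step in this assay is expected, with a somewhat lower number as the likelier direction. The step expected from compound 3 to compound 4 is a 1.4-fold lower number from compound 3 to compound 4 (0.15 log units; within the scatter). Compound 4 is therefore estimated at 1500 nM, within a range from 400 nM to 6000 nM.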

Compound 4, half-maximal inhibitory concentration: 4300 nM
Estimate against measurement, compound 4: 2.9-fold (0.46 log units) below; low and high end bracket the measured number.
By their numbers in this assay, from the lowest: compound 3; then compound 4; then compound 2; then compound 1.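

For the compounds shown here, the first exchange at this aromatic carbon shows in this assay that the group here matters: nitro in place of fluoro gives a 2.0-fold higher number from compound 3 to compound 4 (0.31 log units; beyond the scatter), a modest step that is just beyond the usual scatter. Compound 3 therefore remains the strongest inhibitor measured so far, and replacing its fluoro with nitro brings no gain. Nothing measured here explains this step.

Still open, going by these compounds, is how an amine, a methoxy group or a plain hydrogen at this carbon would compare with fluoro. It is also unknown whether moving fluoro elsewhere on the ring would change the number.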